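This account rests on a few compounds, and the source may have more. Where it says the series, first, only, none or still open, it means among the compounds named here.

Measured so far in a functional assay on MCF7 cells (Homo sapiens) for cytotoxicity, read by MTT assay, with a stated time of 48 h; a lower number here means a stronger inhibitor, a higher number a weaker inhibitor:
- Compound 1 `COc1ccc(-c2nc3ccccn3c2C(=O)/C=C\Nc2cc(OC)cc(OC)c2)cc1`: 14900 nM
- Compound 2 `COc1cc(N/C=C\C(=O)c2c(-c3ccc(Cl)cc3)nc3ccccn23)cc(OC)c1OC`: 3390 nM

Of these two compounds, compound 2 has the lower number and is thus the stronger inhibitor. Its gap to compound 1 lies beyond the usual scatter of repeated measurements. The two compounds differ in more than one place, so this gap cannot be tied to any single structural change.

The next compound, compound 3 `COc1cc(N/C=C\C(=O)c2c(-c3ccc(Cl)cc3)nc3ccccn23)cc(OC)c1`, departs from compound 2 at one place only: hydrogen in place of methoxy on an aromatic carbon. Hydrogen stands in place of methoxy on an aromatic carbon, ortho to two methoxy groups and para to a large group.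

Among the measured compounds shown here, no measured pair shows this change alone. For the measured compounds named here, the only hint comes from compound 1, which also lacks this methoxy but differs elsewhere too, and which reads 14900 nM. A modest loss in this assay is therefore expected, with a step to a higher number just beyond the scatter. The expected step is a 2.2-fold higher number from compound 2 to compound 3 (0.34 log units; beyond the scatter). The estimated value for compound 3 is 7500 nM, with an expected range from 2500 nM to 20000 nM.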

Compound 3, half-maximal inhibitory concentration: 13600 nM
Compound 3: the middle estimate sits 1.8-fold (0.26 log units) below what was measured, within the range that was stated.
By their numbers in this assay, from the lowest: compound 2; then compounds 3 and 1 (each within the scatter of the next).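

In this assay, among the compounds shown here, taking away the methoxy on the aromatic carbon that is ortho to two methoxy groups and para to a large group gives a 4.0-fold higher number from compound 2 to compound 3 (0.60 log units; beyond the scatter), a modest loss that is the first change at this position alone to be read beyond the scatter. The step of a 1.1-fold lower number from compound 1 to compound 3 (0.04 log units; within the scatter), with chloro in place of methoxy on an aromatic carbon, stays within the scatter, so without the methoxy at the first position this second swap shows no measurable effect, and the earlier gap between the two first compounds can now be followed through compound 3 to the missing methoxy. Nothing available here gives a measured reason why this methoxy matters in this assay.

The compounds shown leave open whether the methoxy itself is needed at this position or whether another group on the same carbon, such as a hydroxy group, an ethoxy group or an amine, would serve as well. They also leave open whether chloro and methoxy on the other aromatic carbon would still read alike with all three methoxy groups in place.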